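A few compounds are considered here, and "the series" means these few. Any claim that something is new, unique, unknown or untested is made for them only; others in the source may bear on it.

Measured compounds:
- compound 1, `CCCn1c(Cc2cc(OC)c(OC)c(OC)c2)nc2c(N)ncnc21`: 46800 nM
- compound 2, `CCCn1c(Cc2cc(OC)c(OC)c(OC)c2)nc2c(N)nc(F)nc21`: 25100 nM

In a functional assay on MCF7 cells (Homo sapiens) for antiproliferative activity (on this read-out higher numbers stand for weaker inhibition and lower numbers for stronger inhibition), compound 1 gives 46800 nM, the highest of the two numbers shown, while compound 2 gives 25100 nM. For the measured compounds named here, the one measured step, a 1.9-fold lower number from compound 1 to compound 2 (0.27 log units; within the scatter), changes fluoro in place of hydrogen on an aromatic carbon and stays within the scatter. Compound 3, `COc1cc(Cc2nc3c(N)ncnc3n2CC(C)C)cc(OC)c1OC`, differs from compound 1 by methyl in place of hydrogen on a saturated chain carbon bound to two saturated chain carbons, which the broader cut reads as propyl to isobutyl. Going by the values given here, no measured step touches that saturated chain: the only step available sits on the aromatic ring and itself changed nothing beyond the scatter, so it offers no guidance on the direction of this change. With nothing to argue for a shift, the expected step of a 1.1-fold lower number from compound 1 to compound 3 (0.05 log units; within the scatter) is none beyond the scatter. Compound 3 is therefore estimated at 42000 nM, within a range from 15000 nM to 120000 nM.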

Compound 3, half-maximal inhibitory concentration: 97700 nM
Compound 3: middle estimate off by 2.3-fold (0.37 log units), on the low side, and the stated range covers the measured number.
By their numbers in this assay, from the lowest: compounds 2 and 1 (each within the scatter of the next); then compound 3.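

In this assay, the saturated chain now has a measured step of its own, as a 2.1-fold higher number from compound 1 to compound 3 (0.32 log units; beyond the scatter) comes from propyl to isobutyl, methyl in place of hydrogen on a saturated chain carbon bound to two saturated chain carbons. Though modest, this step lies beyond the scatter, unlike the fluoro change on the aromatic carbon, so a single added methyl at this chain position moves the number upward, toward weaker inhibition. Nothing among the available measurements bears on why this happens. Whether the higher number goes with the branch itself or with a larger chain stays open, since neither a straight butyl chain nor a cyclopropylmethyl group is among the compounds shown. Also open, as far as these compounds go, is how an amine on this chain would read in this assay and whether fluoro would alter the isobutyl compound's number.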